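The source may report more compounds than this note shows. Statements on the series, on what has been measured and on what is new or still open speak of the compounds shown alone.

Compound 1 `CC(CCNC(=O)c1c(Cl)cncc1Cl)N1CCC(C(Oc2ccccn2)c2ccc(C(F)(F)F)cc2)CC1` gives 34100 nM in an ADME assay on PBMC cells (Homo sapiens) for cytotoxicity; on this read-out lower numbers stand for higher toxicity in this test and higher numbers for lower toxicity in this test. Compound 2 `CCO/N=C(/c1ccc(Br)cc1)C1CCN(C(C)CCNC(=O)c2c(Cl)cncc2Cl)CC1` gives 33800 nM in this assay, and compound 3 `CCO/N=C(/c1ccc(Br)cc1)C1CCN(C(C)(C)CCNC(=O)c2c(Cl)cncc2Cl)CC1` gives 34000 nM. Compound 1 holds the highest of the three numbers, yet both neighbours lie within the scatter of it. Among the compounds with values here, the only measured step, a 1.0-fold higher number from compound 2 to compound 3 (0.00 log units; within the scatter), concerns a methyl on the chain and does not touch the aryl ether. Compound 4 `CC(CCNC(=O)c1c(Cl)cncc1Cl)N1CCC(C(Oc2ccccc2C(F)(F)F)c2ccc(C(F)(F)F)cc2)CC1` differs from compound 1 by 2-(trifluoromethyl)phenyl in place of pyridin-2-yl on an oxygen on a saturated carbon. Within the data shown here, no measured step bears on this change, so compound 4 is expected to show no shift beyond the scatter, a step of a 1.0-fold lower number from compound 1 to compound 4 (0.00 log units; within the scatter). The estimate for compound 4 is 34000 nM, within a range from 15000 nM to 70000 nM.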

Compound 4, half-maximal cytotoxic concentration: 12500 nM
Compound 4: middle estimate off by 2.7-fold (0.43 log units), on the high side; measured number below the stated range.
By their numbers in this assay, from the lowest: compound 4; then compounds 2, 3 and 1 (each within the scatter of the next).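

Within the data shown here, at the oxygen on a saturated carbon, the aryl group does register in this assay: 2-(trifluoromethyl)phenyl in place of pyridin-2-yl gives a 2.7-fold lower number from compound 1 to compound 4 (0.44 log units; beyond the scatter), the first step here beyond the scatter. On this read-out, that modest step points towards higher toxicity in this test, whereas the chain methyl step left the number within the scatter. Nothing available accounts for the shift. The compounds shown leave open what a plain phenyl, or a pyridin-2-yl carrying a trifluoromethyl, would give on this oxygen, so the shift cannot yet be assigned to the trifluoromethyl or to the loss of the ring nitrogen.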